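The source may report more compounds than this note shows. Statements on the series, on what has been measured and on what is new or still open speak of the compounds shown alone.

Compound 2 `CCCCCCCCCCCCCOC(=O)CCC(=O)N1CCN(CCCOc2cc3c(Nc4ccc(F)c(Cl)c4)ncnc3cc2OC)CC1` has the shared core joined to a long saturated chain. Within the data shown here, in a functional assay on A549 cells (Homo sapiens) for cytotoxicity, read by MTT assay, with a stated time of 24 h, tested at 20 uM (on this read-out higher numbers stand for a weaker effect at the one concentration tested and lower numbers for a stronger effect), compound 2 gives 93.8%, and the only other number so far, from compound 1 `CCCCCCCCCCOC(=O)CCC(=O)N1CCN(CCCOc2cc3c(Nc4ccc(F)c(Cl)c4)ncnc3cc2OC)CC1`, is separated from it by a gap within the scatter: in this assay compound 1 gives 88.2%. Compound 3 `CCCCCCCCCCCCCCCOC(=O)CCC(=O)N1CCN(CCCOc2cc3c(Nc4ccc(F)c(Cl)c4)ncnc3cc2OC)CC1` carries the chain further: ethyl in place of hydrogen on a saturated chain carbon, ten or more bonds along the chain from an oxygen next to a carbonyl group. Among the measured compounds shown here, the one step of the same kind, a number 5.6 percentage points higher from compound 1 to compound 2 (within the scatter), stayed within the scatter, so no shift beyond the scatter is expected in this assay. Compound 3 is therefore estimated at 94%, between 84% and 100%. The expected step is a number 0.2 percentage points higher from compound 2 to compound 3 (within the scatter).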

Compound 3, a percentage reported as activity, at one concentration (the size of the read-out at that concentration, not a potency): 91.2%
Beside the measured number, compound 3's estimate is 2.8 percentage points above it; the measured number falls inside the stated range.
By their numbers in this assay, from the lowest: compounds 1, 3 and 2 (each within the scatter of the next).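

Placing ethyl at this far position on the chain gives a number 2.6 percentage points lower from compound 2 to compound 3 (within the scatter) and the larger change, pentyl in place of hydrogen, gives a number 3 percentage points higher from compound 1 to compound 3 (within the scatter) as its result. Even this largest change shown therefore leaves the read-out within the scatter, so the three chains cannot be ranked. No measured evidence here explains the closeness of these numbers.

Still open, as far as these compounds go, is whether a much longer chain, or an amine or a carboxylic acid at the far end of the chain, would move the number beyond the scatter.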